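The source may report more compounds than this note shows. Statements on the series, on what has been measured and on what is new or still open speak of the compounds shown alone.

Compound 1 `CCCCN(C)CCCO/N=C(\c1ccc(SC)cc1)c1cccc2ccccc12` — in a functional assay on MDA-MB-231 cells (Homo sapiens) for antiproliferative activity, read by MTT assay, with a stated time of 24 h (a higher number here means that more compound is needed for the effect, a lower number that less compound is needed), compound 1 gives > 50000 nM, which is a limit of the assay.
Compound 2 `CSc1ccc(/C(=N\OCCCCN2CCCCC2)c2cccc3ccccc23)cc1` — in this assay compound 2 gives 18000 nM.
Compound 3 `CSc1ccc(/C(=N\OCCCCN2CCCC2)c2cccc3ccccc23)cc1` — in this assay compound 3 gives > 50000 nM, again a limit of the assay.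

Compound 3 thus stands at the limit of > 50000 nM in this assay, at which 2 of the 3 values shown sit, and only compound 2 yields a number. The step of an at least 2.7-fold higher number from compound 2 to compound 3 (0.44 log units; beyond the scatter) shows the pyrrolidine leaving the readable range, whereas a step that the two limits leave unreadable from compound 1 to compound 3 cannot be sized. The change now considered is benzyl(ethyl)amino in place of pyrrolidin-1-yl on a saturated chain carbon, four bonds along the chain from an oxygen, which gives compound 4 `CCN(CCCCO/N=C(\c1ccc(SC)cc1)c1cccc2ccccc12)Cc1ccccc1`. Both steps into compound 3 bear on it: the acyclic amine of compound 1 also sat at the limit, and only the larger ring of compound 2 produced a number, so the larger acyclic amine of compound 4 is expected to move the number at most modestly, if at all, and the expected step is an at least 1.6-fold lower number from compound 3 to compound 4 (0.22 log units; that floor lies within the scatter). Compound 4 is therefore estimated at 30000 nM, within 8000 nM to 100000 nM.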

Compound 4, half-maximal effective concentration: > 50000 nM
Compound 4: a limit, no number (the forecaster's own chance of this, stated with the estimate: 50%); middle value at least 1.6-fold (0.22 log units) away from the limit.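

With the larger benzyl(ethyl)amino taking over from piperidin-1-yl, the readable result of the piperidine is lost, with an at least 2.7-fold higher number from compound 2 to compound 4 (0.44 log units; beyond the scatter). The steps to compound 4 from compound 1 and from compound 3 join two limits and cannot be read. So a group carrying an aromatic ring at this place does not bring a number back in this assay, and compound 4 joins compound 1 and compound 3 at a limit of the assay: the limit of > 50000 nM in this assay, at which 3 of the 4 values shown sit.

Among these compounds piperidin-1-yl alone gives a number, and how much the three compounds at the limit differ from one another remains open. On these data alone, whether a morpholine or an azepane at this place would also give a number is likewise open.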